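Swapping 3-bromo-4-fluorophenyl for pyridin-3-yl in compound 3

The source may report more compounds than this note shows. Statements on the series, on what has been measured and on what is new or still open speak of the compounds shown alone.

In an in vitro ADME assay on microsomes from liver (Mus musculus) for pharmacokinetics, read by LC-MS, with a stated time of 10 min, tested at 1 uM (a lower number here means slower removal, a higher number faster removal of the compound), compound 1 (`CN1C[C@H](C(=O)Nc2ccccc2)[C@@H](c2ccc(/C=C/C(=O)Nc3ccccc3N)cc2)C1`) gives 67 mL/min/kg, compound 2 (`CN1C[C@H](C(=O)Nc2ccc(F)c(F)c2)[C@@H](c2ccc(/C=C/C(=O)Nc3ccccc3N)cc2)C1`) gives 46 mL/min/kg and compound 3 (`CN1C[C@H](C(=O)Nc2ccc(F)c(Br)c2)[C@@H](c2ccc(/C=C/C(=O)Nc3ccccc3N)cc2)C1`) gives 43 mL/min/kg. All three lie within the usual scatter of one another, so compound 3 cannot be told apart from the other two. Compound 4 (`CN1C[C@H](C(=O)Nc2cccnc2)[C@@H](c2ccc(/C=C/C(=O)Nc3ccccc3N)cc2)C1`) carries pyridin-3-yl in place of 3-bromo-4-fluorophenyl on an amide-type nitrogen. For the measured compounds named here, no measured compound holds pyridin-3-yl, so the closest guides are the changes at this same nitrogen, a 1.6-fold lower number from compound 1 to compound 3 (0.19 log units; within the scatter) and a 1.5-fold lower number from compound 1 to compound 2 (0.16 log units; within the scatter). The smaller related step is a 1.1-fold lower number from compound 2 to compound 3 (0.03 log units; within the scatter). All are small, so a modest move is expected in this assay. The expected step is a 1.3-fold higher number from compound 3 to compound 4 (0.11 log units; within the scatter), with none foreseen beyond the scatter. For compound 4 the estimated clearance is 55 mL/min/kg, within an expected range of 30 mL/min/kg to 95 mL/min/kg.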

Compound 4, clearance: 41 mL/min/kg
The estimate for compound 4 lay 1.3-fold (0.13 log units) above the measured number; the range from low to high includes it.
By their numbers in this assay, from the lowest: compounds 4, 3, 2 and 1 (each within the scatter of the next).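

In this assay, pyridin-3-yl on the amide-type nitrogen cannot be told apart from any of the carbon-only rings tested there (a 1.0-fold lower number from compound 3 to compound 4 (0.02 log units; within the scatter); a 1.1-fold lower number from compound 2 to compound 4 (0.05 log units; within the scatter); a 1.6-fold lower number from compound 1 to compound 4 (0.21 log units; within the scatter)). Across these four compounds, then, a ring with a hetero atom at this position gives a clearance within the scatter of the phenyl and halogenated phenyl rings. No measurement shown accounts for this result. Still open, going by these compounds, is whether a non-aromatic group on this nitrogen, such as a plain alkyl chain or a carboxylic acid, would shift clearance beyond the scatter.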